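A few compounds are considered here, and "the series" means these few. Any claim that something is new, unique, unknown or untested is made for them only; others in the source may bear on it.

Three amides built on one shared core have been tested in a functional assay on Bel-7402 cells (Homo sapiens) for cytotoxicity, read by MTT assay; on this read-out higher numbers stand for weaker inhibition and lower numbers for stronger inhibition. Compound 1 `CCn1cc(C(=O)Nc2ccccc2O)c(=O)c2cc(F)c(N3CCNC(C)C3)c(F)c21` reads > 50000 nM, which is a limit of the assay and not a number. Compound 2 `CCn1cc(C(=O)Nc2ccccc2N)c(=O)c2cc(F)c(N3CCNC(C)C3)c(F)c21` gives 4800 nM. Going by the values given here, compound 3 `CCn1cc(C(=O)Nc2ccc(OC(F)(F)F)cc2)c(=O)c2cc(F)c(N3CCNC(C)C3)c(F)c21` gives 2000 nM, the lowest number so far. Compound 4 `CCn1cc(C(=O)Nc2nccs2)c(=O)c2cc(F)c(N3CCNC(C)C3)c(F)c21` carries 1,3-thiazol-2-yl in place of 4-(trifluoromethoxy)phenyl on an amide-type nitrogen. Two measured swaps at this nitrogen bear on it: the large at least 25-fold lower number from compound 1 to compound 3 (1.39 log units; beyond the scatter) and the modest 2.4-fold lower number from compound 2 to compound 3 (0.38 log units; beyond the scatter). With the modest 2.4-fold lower number from compound 2 to compound 3 (0.38 log units; beyond the scatter) as the closer guide, a modest rise is expected in this assay, though a larger one is possible. The estimated change is a 2.5-fold higher number from compound 3 to compound 4 (0.40 log units; beyond the scatter). For compound 4 the expected value is 5000 nM, within an estimated range of 1500 nM to 25000 nM.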

Compound 4, half-maximal inhibitory concentration: > 50000 nM
Compound 4 ended at the assay's limit; the forecaster's own chance of this, stated with the estimate: 12%; at least 10-fold (1.00 log units) between middle value and limit.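

The change to 1,3-thiazol-2-yl on this amide-type nitrogen gives an at least 25-fold higher number from compound 3 to compound 4 (1.39 log units; beyond the scatter) and an at least 10-fold higher number from compound 2 to compound 4 (1.01 log units; beyond the scatter). So the read-out at this position can be lost with a five-membered ring as well as with the 2-hydroxyphenyl of compound 1, while the 2-aminophenyl of compound 2 and the 4-(trifluoromethoxy)phenyl of compound 3 keep a readable number. The step from compound 1 to compound 4 cannot be read, and the value of compound 4 is a limit, not a number: the limit of > 50000 nM in this assay, at which 2 of the 4 values shown sit.

As far as these compounds go, whether the five-membered ring itself matters, or only the absence of a phenyl ring, stays open; an unsubstituted phenyl or a pyridin-2-yl on the same nitrogen would help separate the two. From the compounds shown here alone, how far compound 4 lies beyond its limit also stays unknown.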